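Dichlorophenyl Analogue in the Cytotoxicity Series

The compounds below may be only part of what the source reports. "The series", "measured", "known", "first", "only" and "open" are said of these compounds alone.

Compound 1, `Clc1cccc([C@@H]2C[C@@H]3Cc4ccc5ccccc5c4N2O3)c1`: in an ADME assay on Vero cells (Chlorocebus sabaeus) for cytotoxicity, read by MTT assay, with a stated time of 72 h (a higher number here means that more compound is tolerated, a lower number that less compound is tolerated), compound 1 gives > 300000 nM, which is a limit of the assay.
Compound 2, `Cc1cccc([C@@H]2C[C@@H]3Cc4ccc5ccccc5c4N2O3)c1`: in this assay compound 2 gives > 300000 nM, again a limit of the assay.

For the measured compounds named here, compound 2 therefore stands only at a limit, not at a number, and the one further value shown is a limit as well. The step that the two limits leave unreadable from compound 1 to compound 2 accordingly cannot be read, neither in size nor in direction. What both values have in common is the limit of > 300000 nM in this assay, at which 2 of the 2 values shown sit.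

Compound 3, `Clc1ccc([C@@H]2C[C@@H]3Cc4ccc5ccccc5c4N2O3)c(Cl)c1`, arises from compound 2 by 2,4-dichlorophenyl in place of 3-methylphenyl on a saturated ring carbon. Going by the values given here, no measured step bears directly on a change of this kind; the only step available, a step that the two limits leave unreadable from compound 1 to compound 2, is unreadable. The expectation for compound 3 in this assay is therefore a position at the limit once more. The step of a number no higher from compound 2 to compound 3 (the limit leaves the size open) is thus expected to be none beyond the scatter. Compound 3 is estimated at 300000 nM, with a range from 100000 nM to 1000000 nM, and most likely the assay again reports only a limit.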

Compound 3, half-maximal cytotoxic concentration: 55000 nM
Compound 3: middle estimate off by 5.5-fold (0.74 log units), on the high side, outside the stated range (below it).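

For the compounds shown here, this position on the saturated ring carbon is not indifferent to the aryl group it carries in this assay: the 2,4-dichlorophenyl group gives the first readable steps, one against 3-methylphenyl (an at least 5.4-fold lower number from compound 2 to compound 3 (0.73 log units; beyond the scatter)) and one against 3-chlorophenyl (an at least 5.4-fold lower number from compound 1 to compound 3 (0.73 log units; beyond the scatter)). Both steps lie beyond the scatter, each is only a minimum size with a limit at its start, and the step between compound 1 and compound 2 still cannot be read. Compound 3 alone of the three gives a number, while compound 1 and compound 2 share a single limit: the limit of > 300000 nM in this assay, at which 2 of the 3 values shown sit.

The compounds shown leave open whether the step belongs to the 2,4-dichlorophenyl group as a whole or would also appear with a single chlorine on the phenyl ring, as in 2-chlorophenyl or 4-chlorophenyl. They also leave open how the number would move with an amine or a carboxylic acid on that ring, and how large the two steps truly are.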